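A few compounds are considered here, and "the series" means these few. Any claim that something is new, unique, unknown or untested is made for them only; others in the source may bear on it.

Working notes on the series. The shared core is carried by compound 1 `COc1ccc(-c2cn3cc(C4=CCN(C(=O)c5ccccc5C(F)(F)F)CC4)ccc3n2)cc1OC`, compound 2 `COc1ccc(-c2cn3cc(C4=CCN(C(=O)C(C)(C)C)CC4)ccc3n2)cc1OC` and compound 3 `COc1ccc(-c2cn3cc(C4=CCN(S(=O)(=O)C5CCCC5)CC4)ccc3n2)cc1OC`. In a functional assay on A549 cells (Homo sapiens) for antiproliferative activity, read by MTT assay, with a stated time of 48 h (a higher number here means a weaker inhibitor, a lower number a stronger inhibitor), compound 1 gives 2550 nM, compound 2 gives 4340 nM and compound 3 gives 6470 nM, the highest of the three numbers; its gap to compound 2 is within the scatter, its gap to compound 1 beyond it. Compound 4 `COc1ccc(-c2cn3cc(C4=CCN(C(=O)c5cccs5)CC4)ccc3n2)cc1OC` differs from compound 3 by (thiophen-2-yl)carbonyl in place of cyclopentylsulfonyl on an amine nitrogen in a ring. The step that bears most on this change is a 2.5-fold higher number from compound 1 to compound 3 (0.40 log units; beyond the scatter), in which an aryl carbonyl is replaced by the sulfonyl; a 1.5-fold higher number from compound 2 to compound 3 (0.17 log units; within the scatter) was smaller. Going back to a heteroaryl carbonyl, a modest lower number is expected, a 2.0-fold lower number from compound 3 to compound 4 (0.31 log units; beyond the scatter). Compound 4 is therefore estimated at 3200 nM, with a range from 1500 nM to 6800 nM.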

Compound 4, half-maximal inhibitory concentration: 5200 nM
For compound 4 the middle estimate is 1.6-fold (0.21 log units) below the measured one; the measured number falls inside the stated range.
By their numbers in this assay, from the lowest: compounds 1, 2, 4 and 3 (each within the scatter of the next, the first and the last beyond it).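

In (this assay), (thiophen-2-yl)carbonyl and cyclopentylsulfonyl on the amine nitrogen in a ring are not separated (a 1.2-fold lower number from compound 3 to compound 4 (0.09 log units; within the scatter)), and neither are thiophen-2-yl and tert-butyl on the carbonyl carbon (a 1.2-fold higher number from compound 2 to compound 4 (0.08 log units; within the scatter)). Only 2-(trifluoromethyl)phenyl stands apart from thiophen-2-yl (a 2.0-fold higher number from compound 1 to compound 4 (0.31 log units; beyond the scatter)), so the thiophene ring alone does not reproduce the number of compound 1. No evidence at hand bears on the cause of these steps. Open, as far as these compounds go, is whether an unsubstituted phenyl on the carbonyl carbon would stay with compound 1 or with compound 4, and whether an amine or a carboxylic acid there would shift the number beyond the scatter.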